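The compounds below may be only part of what the source reports. "The series", "measured", "known", "first", "only" and "open" are said of these compounds alone.

In a functional assay on PC-3 cells (Homo sapiens) for cytotoxicity, read by sulforhodamine B assay, with a stated time of 48 h, tested at 100 nM (on this read-out lower numbers stand for a stronger effect and higher numbers for a weaker effect at the one concentration tested), compound 2 `COc1cc(C)cc(-c2nn(CC#N)cc2-c2ccnc(-c3ccc(N(C)C)cc3)c2)c1` gives 14%. Compound 1 `COc1cc(C)cc(-c2c(-c3ccnc(-c4ccc(N(C)C)cc4)c3)cnn2CC#N)c1` gives 11% in this assay, a number within the scatter of compound 2, so the two stand together. Compound 3 `COc1cc(C)cc(-c2nn(CC#N)cc2-c2ccc(-c3cccc(C(C)=O)c3)nc2)c1` gives 85% in this assay, far higher than compound 2 and beyond the scatter; compound 3 keeps the shared core but carries a different pendant ring. Compound 4 `Cc1cc(O)cc(-c2nn(CC#N)cc2-c2ccnc(-c3ccc(N(C)C)cc3)c2)c1` is not yet measured in this assay. It differs from compound 2 by hydrogen in place of methyl on an oxygen on an aromatic ring. Going by the values given here, no measured pair shows this change, so its size is not known; since only a methyl leaves and the rest of compound 2 is kept, the expected step from compound 2 to compound 4 is a number 6 percentage points higher from compound 2 to compound 4 (within the scatter), within the scatter or little beyond it. Compound 4 is estimated at 20% in this assay, between 6% and 50%.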

Compound 4, a percentage reported as activity, at one concentration (the size of the read-out at that concentration, not a potency): 94%
Beside the measured number, compound 4's estimate is 74 percentage points below it; the measured number lies above the stated range.
By their numbers in this assay, from the lowest: compounds 1 and 2 (each within the scatter of the next); then compounds 3 and 4 (each within the scatter of the next).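

In this assay, going from methoxy to hydroxy on the aromatic ring gives a number 80 percentage points higher from compound 2 to compound 4 (beyond the scatter), so this oxygen's methyl is far from a silent part of compound 2. The removal of one heavy atom, with the rest of compound 2 kept, is enough to lose nearly all of the effect at the one concentration tested. Nothing at hand accounts for the size of this step.

Open, going by these compounds, is whether an ethoxy group, an amine or a fluorine at this place would keep the effect. Also open, on these data alone, is whether the same change would carry the same step on compound 1.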